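The source may report more compounds than this note shows. Statements on the series, on what has been measured and on what is new or still open speak of the compounds shown alone.

Working notes on the series in a functional assay on RAW264.7 cells (Mus musculus) for inhibition, read by Griess assay, with stated times of 2 h and 24 h; on this read-out higher numbers stand for weaker inhibition and lower numbers for stronger inhibition.

Compound 3 `COc1ccc([C@@H]2CC(=O)c3c(O)cc(OCc4cn(CC5CC5)nn4)cc3O2)cc1O` gives 11900 nM. Among the three measured compounds this places compound 3 second highest: compound 1 `C#CCOc1cc(O)c2c(c1)O[C@H](c1ccc(OC)c(O)c1)CC2=O` gives 20900 nM, and the step of a 1.8-fold lower number from compound 1 to compound 3 (0.24 log units; within the scatter) lies within the scatter. Within the data shown here, compound 2 `COc1ccc([C@@H]2C/C(=N\O)c3c(O)cc(OCc4cn(Cc5ccccc5F)nn4)cc3O2)cc1O` gives 5710 nM, a lower number beyond the scatter from compound 3, but compound 2 differs from compound 3 in more than one place, so no single step can be drawn from that pair.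

Compound 4 `COc1ccc([C@@H]2CC(=O)c3c(O)cc(OCc4cn(Cc5cccc(C)c5)nn4)cc3O2)cc1O` is not yet measured. The change from compound 3 is 3-methylphenyl in place of cyclopropyl on a saturated chain carbon bound to an aromatic nitrogen. Among the measured compounds shown here, the only measured step that touches the same region, the step from compound 1 to compound 3, swaps the whole group on the chain carbon bound to the aromatic ring oxygen and is within the scatter; it says little about exchanging cyclopropyl for 3-methylphenyl on the chain carbon bound to the aromatic nitrogen. Compound 2, which carries a benzyl-type group there, gives the lowest number, but its second difference clouds that reading.

The expectation for compound 4 is therefore a modest move to a lower number, a 1.6-fold lower number from compound 3 to compound 4 (0.20 log units; within the scatter), with wide uncertainty. The estimate for compound 4 in this assay is 7500 nM, expected to fall between 3000 nM and 18000 nM.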

Compound 4, half-maximal inhibitory concentration: 17400 nM
Compound 4: the middle estimate sits 2.3-fold (0.37 log units) below what was measured; the measured number falls inside the stated range.
By their numbers in this assay, from the lowest: compound 2; then compounds 3, 4 and 1 (each within the scatter of the next).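

In this assay, among these compounds, the step of a 1.5-fold higher number from compound 3 to compound 4 (0.17 log units; within the scatter) is the first single-place reading on the saturated chain carbon bound to an aromatic nitrogen. Cut one bond further out, it reads cyclopropylmethyl to 3-methylbenzyl: a three-membered non-aromatic ring of 3 heavy atoms gives way to a six-membered aromatic ring group of 7 heavy atoms, and the number is not resolved from the earlier one. No measurement at hand bears on why the two groups cannot be told apart here.

From the compounds shown here alone, whether any group at this place can move the number beyond the scatter stays open, for example a chain ending in an amine or a carboxylic acid. Also open, going by these compounds, is whether the same exchange would read alike with the oxime of compound 2 in the core.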